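The source may report more compounds than this note shows. Statements on the series, on what has been measured and on what is new or still open speak of the compounds shown alone.

Measured compounds:
compound 1 `CN(C(=O)NC(=O)c1c(F)cccc1F)c1nc(C(F)(F)F)c(C(=O)N/N=C/c2cccc(C(F)(F)F)c2)s1`, 27.9 ug/mL
compound 2 `Cc1nc(N(C)C(=O)NC(=O)c2c(F)cccc2F)sc1C(=O)N/N=C/c1cccc(C(F)(F)F)c1`, 31.6 ug/mL

In a functional assay on HepG2 cells (Homo sapiens) for inhibition, read by MTT assay, with a stated time of 72 h (on this read-out lower numbers stand for stronger inhibition and higher numbers for weaker inhibition), compound 2 gives 31.6 ug/mL, and compound 1 gives 27.9 ug/mL; the two numbers lie within the scatter of each other, so neither stands apart. Among the compounds with values here, the one measured step, a 1.1-fold higher number from compound 1 to compound 2 (0.05 log units; within the scatter), concerns the group on the shared core and not the hydrazone-linked ring. Compound 3 `Cc1nc(N(C)C(=O)NC(=O)c2c(F)cccc2F)sc1C(=O)N/N=C/c1ccccc1` differs from compound 2 in that ring: hydrogen in place of trifluoromethyl on an aromatic carbon. Within the data shown here, no measured step touches this position, so nothing recorded points to a direction. Without a shown step to lean on, the change is expected to leave this assay close to where compound 2 stands, with the middle of the guess tilted slightly toward a higher number; the expected step is a 1.3-fold higher number from compound 2 to compound 3 (0.10 log units; within the scatter). The estimate for compound 3 is 40 ug/mL, with a range from 18 ug/mL to 90 ug/mL.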

Compound 3, half-maximal inhibitory concentration: 54.3 ug/mL
Compound 3: middle estimate off by 1.4-fold (0.13 log units), on the low side; low and high end bracket the measured number.
By their numbers in this assay, from the lowest: compounds 1, 2 and 3 (each within the scatter of the next).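

This is the only step shown on the six-membered aromatic ring of carbon only, and in this assay swapping trifluoromethyl for hydrogen there gives a 1.7-fold higher number from compound 2 to compound 3 (0.24 log units; within the scatter), so the two compounds cannot be told apart. The trifluoromethyl group at this place is therefore not required for compound 3 to read within the scatter of compound 2, and the result adds a second position to the one on the shared core where a single change stays within the scatter. Nothing on hand speaks to the reason for the size of this step.

Still open, on these data alone, is whether an amine, a carboxylic acid or a methoxy group at this place would give a step beyond the scatter. As far as these compounds go, a longer chain in place of the methyl on an aromatic carbon of the shared core is equally open.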